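Three Aryl Groups, One Level of Activity

The compounds below may be only part of what the source reports. "The series", "measured", "known", "first", "only" and "open" are said of these compounds alone.

In a functional assay with Homo sapiens as the target (a higher number here means a weaker inhibitor, a lower number a stronger inhibitor), compound 1 `CC(C)[C@H](NC(=O)COc1cccc2ccccc12)C(=O)N[C@@H](CC(=O)O)C(=O)COc1ccc(-c2ccccc2)cc1` gives 38700 nM, compound 2 `CC(C)[C@H](NC(=O)COc1cccc2ccccc12)C(=O)N[C@@H](CC(=O)O)C(=O)COc1ccc(C#N)cc1` gives 26700 nM and compound 3 `CC(C)[C@H](NC(=O)COc1cccc2ccccc12)C(=O)N[C@@H](CC(=O)O)C(=O)COc1ccccc1[N+](=O)[O-]` gives 27700 nM. Compound 3 therefore sits level with the other two, since all three values lie within the scatter of one another.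

The next compound, compound 4 `CC(C)[C@H](NC(=O)COc1cccc2ccccc12)C(=O)N[C@@H](CC(=O)O)C(=O)COc1ccc(F)cc1F`, differs from compound 3 in one place: 2,4-difluorophenyl in place of 2-nitrophenyl on an oxygen on a saturated carbon. There, 2,4-difluorophenyl stands in place of 2-nitrophenyl on an oxygen on a saturated carbon. Within the data shown here, no measured compound carries fluorine at this place, so the evidence is indirect.

At the same place, 2-nitrophenyl in place of 4-cyanophenyl gave a 1.0-fold higher number from compound 2 to compound 3 (0.02 log units; within the scatter), and 2-nitrophenyl in place of 4-phenylphenyl gave a 1.4-fold lower number from compound 1 to compound 3 (0.15 log units; within the scatter). Cyano in place of phenyl gave a 1.4-fold lower number from compound 1 to compound 2 (0.16 log units; within the scatter). None of these three steps leaves the scatter, so no step beyond the scatter is expected here, in either direction. The expected change is a 1.1-fold higher number from compound 3 to compound 4 (0.03 log units; within the scatter). For compound 4 the estimate is 30000 nM, with an expected range from 15000 nM to 60000 nM.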

Compound 4, half-maximal inhibitory concentration: 17600 nM
Estimate against measurement, compound 4: 1.7-fold (0.23 log units) above; the range from low to high includes it.
By their numbers in this assay, from the lowest: compounds 4, 2, 3 and 1 (each within the scatter of the next, the first and the last beyond it).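

In this assay the 2,4-difluorophenyl group, the only one here carrying fluorine at this place, stands level with 2-nitrophenyl and 4-cyanophenyl, with a 1.6-fold lower number from compound 3 to compound 4 (0.20 log units; within the scatter) and a 1.5-fold lower number from compound 2 to compound 4 (0.18 log units; within the scatter) as the two steps. Among these compounds, measured against 4-phenylphenyl, the change gives a 2.2-fold lower number from compound 1 to compound 4 (0.34 log units; beyond the scatter) and is the only step at this place that leaves the scatter, so the choice of aryl group on this oxygen can move the number, though only modestly. Nothing measured here explains that step.

The compounds shown cannot separate the effect of adding the two fluorine atoms from that of removing the outer phenyl ring of 4-phenylphenyl, a question that a plain phenyl or a 4-fluorophenyl group at this place would help to answer. Going by these compounds, how a saturated group such as cyclohexyl or a short chain such as ethyl would behave on this oxygen also stays open.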